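Morpholine amide chain in place of pyrrolidine on a carbonyl

The source may report more compounds than this note shows. Statements on the series, on what has been measured and on what is new or still open speak of the compounds shown alone.

Measured compounds:
compound 1 `COc1ncc(-c2ccc3nc(NC(=O)N4CCCC4)nn3c2)cc1NS(=O)(=O)c1ccc(F)cc1` gives 3570 nM
compound 2 `CNC(=O)Nc1nc2ccc(-c3cnc(OC)c(NS(=O)(=O)c4ccc(F)cc4)c3)cn2n1` gives 230 nM
compound 3 `COc1ncc(-c2ccc3nc(NC(=O)NCCN4CCN(C)CC4)nn3c2)cc1NS(=O)(=O)c1ccc(F)cc1` gives 1050 nM

In a functional assay on A549 cells (Homo sapiens) for cytotoxicity, read by MTT assay, with a stated time of 72 h (a lower number here means a stronger inhibitor, a higher number a weaker inhibitor), compound 1 stands as the highest of the three numbers; its nearest neighbour is compound 3 and its furthest is compound 2. Compound 4 `COc1ncc(-c2ccc3nc(NC(=O)NCC(=O)N4CCOCC4)nn3c2)cc1NS(=O)(=O)c1ccc(F)cc1` has not yet been measured. It differs from compound 1 at one place: (((morpholin-4-yl)carbonyl)methyl)amino in place of pyrrolidin-1-yl on a carbonyl carbon.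

Within the data shown here, two measured steps bear on this change, since each replaces the pyrrolidin-1-yl on the same carbonyl carbon with an amino group carrying one hydrogen-bond donor. The step of a 16-fold lower number from compound 1 to compound 2 (1.19 log units; beyond the scatter) was large, while the step of a 3.4-fold lower number from compound 1 to compound 3 (0.53 log units; beyond the scatter) was modest. Compound 4, like compound 3, carries a chain ending in a saturated six-membered ring on that amino group rather than a bare methyl, so the step into compound 4 is expected to resemble the step into compound 3 more than the step into compound 2. The expected step is therefore a modest lowering in this assay, a 4.0-fold lower number from compound 1 to compound 4 (0.60 log units; beyond the scatter). Compound 4 is estimated at 900 nM, within a range from 350 nM to 2500 nM.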

Compound 4, half-maximal inhibitory concentration: 2570 nM
For compound 4 the middle estimate is 2.9-fold (0.46 log units) below the measured one; the whole stated range lies below it.
By their numbers in this assay, from the lowest: compound 2; then compound 3; then compounds 4 and 1 (each within the scatter of the next).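

In this assay, replacing pyrrolidin-1-yl on the carbonyl carbon with an amino group does not in itself lower the number, for the result is a 1.4-fold lower number from compound 1 to compound 4 (0.14 log units; within the scatter), whereas compounds 2 and 3 had both pointed to a drop. What the amino group carries therefore decides the outcome at this position: the change of chain end gives a 2.4-fold higher number from compound 3 to compound 4 (0.39 log units; beyond the scatter), so a chain ending in a saturated six-membered ring does not fix the value. The largest effect comes from adding (morpholin-4-yl)carbonyl to the small methyl-bearing chain, which gives an 11-fold higher number from compound 2 to compound 4 (1.05 log units; beyond the scatter).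

The compounds shown leave open whether an ethyl group, a carboxylic acid or a simple dimethylamide at the chain end would keep the number near that of compound 2. Nothing given here accounts for these differences.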